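The compounds below may be only part of what the source reports. "The series", "measured", "known", "first", "only" and "open" are said of these compounds alone.

Compound 1 `COC(=O)[C@@]1(C)CCC=C2[C@@H]1CC[C@@H](C)[C@]2(C)Cc1c[nH]c2ccc(Cl)cc12` gives 11000 nM in a functional assay on HeLa cells (Homo sapiens) for inhibition, read by sulforhodamine B assay, with a stated time of 48 h; on this read-out lower numbers stand for stronger inhibition of growth and higher numbers for weaker inhibition of growth. Compound 2 `COC(=O)[C@@]1(C)CCC=C2[C@@H]1CC[C@@H](C)[C@]2(C)Cc1c[nH]c2ccc(F)cc12` gives 3700 nM. Compound 3 `COC(=O)[C@@]1(C)CCC=C2[C@@H]1CC[C@@H](C)[C@]2(C)Cc1c[nH]c2ccc(C(F)(F)F)cc12` gives 11000 nM.

Compound 1 stands level with compound 3, the pair sharing the highest numbers of the three, and so the weakest growth inhibition: no change at the digits printed from compound 1 to compound 3 (within the scatter), while a 3.0-fold lower number from compound 1 to compound 2 (0.47 log units; beyond the scatter). Compound 4 `COC(=O)[C@@]1(C)CCC=C2[C@@H]1CC[C@@H](C)[C@]2(C)Cc1c(C)[nH]c2ccc(Cl)cc12` differs from compound 1 in one spot: methyl in place of hydrogen on an aromatic carbon. The measured steps all exchange one group for another on the six-membered part of the core and leave the five-membered ring untouched, so none of them bears on this change; they only show that a single-group swap on this core moves the number modestly at most. The step is therefore expected to stay within the scatter, no change at the digits printed from compound 1 to compound 4 (within the scatter). Compound 4 is estimated at 11000 nM, within 4000 nM to 30000 nM.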

Compound 4, concentration for 50% growth inhibition: 12000 nM
Beside the measured number, compound 4's estimate is 1.1-fold (0.04 log units) below it; the measured number falls inside the stated range.
By their numbers in this assay, from the lowest: compound 2; then compounds 1, 3 and 4 (each within the scatter of the next).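

Among the compounds shown here, this position on the five-membered aromatic ring, next to the ring nitrogen, is one the earlier compounds left untouched, and in this assay a methyl in place of hydrogen there gives a 1.1-fold higher number from compound 1 to compound 4 (0.04 log units; within the scatter), so growth inhibition stays where it was. A methyl at this position thus brings neither gain nor loss on the chloro compound. Nothing shown here explains why the number holds.

As far as these compounds go, whether an amine, a carboxylic acid or a longer chain at this position would also leave the number alone stays open. So does whether methyl here would behave the same alongside the fluoro of compound 2.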